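Replacing the sulfamoylphenyl of compound 3 with a fluoropyridyl

The source may report more compounds than this note shows. Statements on the series, on what has been measured and on what is new or still open speak of the compounds shown alone.

Compound 3 `NS(=O)(=O)c1ccc(-c2nc(C(c3ccc(F)cc3)c3ccc(F)cc3)sc2CC(=O)O)cc1` stands only at a limit in an in vitro functional assay on HEK285-7 cells for antagonist activity at prostaglandin D2 receptor 2 (Homo sapiens), read by BRET and beta-arrestin recruitment; on this read-out higher numbers stand for weaker inhibition and lower numbers for stronger inhibition: compound 3 gives > 100000 nM, a limit of the assay rather than a number. Compound 1 `O=C(O)Cc1sc(C(c2ccccc2)c2ccccc2)nc1-c1ccc(F)c(F)c1` gives 43 nM in this assay. Compound 2 `O=C(O)Cc1sc(C(c2ccccc2)c2ccccc2)nc1-c1ccc(C(F)(F)F)cc1` reaches only a limit, > 100000 nM, so (the limit of > 100000 nM in this assay, at which 2 of the 3 values shown sit). Going by the values given here, the single measured step at this position, an at least 2300-fold higher number from compound 1 to compound 2 (3.36 log units; beyond the scatter), shows that the group on this aromatic carbon can decide everything. Compound 4 `O=C(O)Cc1sc(C(c2ccc(F)cc2)c2ccc(F)cc2)nc1-c1ccnc(F)c1` is compound 3 with 2-fluoropyridin-4-yl in place of 4-sulfamoylphenyl on an aromatic carbon. Among the compounds with values here, no measured step covers this exact change; the estimate leans on compound 1, whose 3,4-difluorophenyl gives 43 nM. Compound 4 is therefore expected to improve to about 300 nM (between 30 nM and 30000 nM), a step of an at least 330-fold lower number from compound 3 to compound 4 (2.52 log units; beyond the scatter), with a real chance that the assay again reports only a limit.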

Compound 4, half-maximal inhibitory concentration: 4.7 nM
Compound 4: middle estimate off by 64-fold (1.81 log units), on the high side, and the stated range ends above it.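

In this assay, going by these compounds alone, 2-fluoropyridin-4-yl in place of 4-sulfamoylphenyl gives an at least 21000-fold lower number from compound 3 to compound 4 (4.32 log units; beyond the scatter), the first step at this position towards stronger inhibition. The core of compound 3 therefore does not itself hold the read-out at the limit, and the group on this aromatic carbon can restore strong inhibition. Because compound 3 stands at a limit of the assay, this step is a bound and not a measured size: the limit of > 100000 nM in this assay, at which 2 of the 4 values shown sit.

The compounds shown leave open whether the ring nitrogen or the fluorine of the entering group carries the gain, which a plain pyridin-4-yl or a 3-fluorophenyl would separate. From the compounds shown here alone, how a 2-aminopyridin-4-yl would read at this position also remains open.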